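The compounds below may be only part of what the source reports. "The series", "measured", "known", "first", "only" and "open" are said of these compounds alone.

Measured compounds in a functional assay on aorta (Rattus norvegicus, strain Wistar) for inhibition, with a stated time of 60 min; on this read-out higher numbers stand for an effect only at larger amounts of compound and lower numbers for an effect already at smaller amounts:
compound 1 `CCCOc1ccc(-c2nc3cc(C(F)(F)F)ccc3[nH]2)cc1` gives 524000 nM
compound 2 `FC(F)(F)c1ccc2[nH]c(-c3ccccc3)nc2c1` gives 369000 nM
compound 3 `COc1ccc(-c2nc3cc([N+](=O)[O-])ccc3[nH]2)c(OC)c1OC` gives 3230 nM

Compound 2 has the second highest of the three numbers; compound 1 stands nearest, compound 3 furthest with a number lower by far beyond the scatter. Compound 4 `CCOc1ccccc1-c1nc2cc(C(F)(F)F)ccc2[nH]1` differs from compound 2 by ethoxy in place of hydrogen on an aromatic carbon. Within the data shown here, the only measured step that bears on this is a 1.4-fold lower number from compound 1 to compound 2 (0.15 log units; within the scatter), an alkoxy removal that stayed within the scatter; the present change runs the other way, adding a short alkoxy chain at a different place. Among the measured compounds shown here, no measured step covers an ortho substituent. Compound 4 is therefore expected to show no change beyond the scatter, a 1.0-fold higher number from compound 2 to compound 4 (0.01 log units; within the scatter). The estimate for compound 4 is 380000 nM, within 150000 nM to 950000 nM.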

Compound 4, half-maximal effective concentration: 549000 nM
The estimate for compound 4 lay 1.4-fold (0.16 log units) below the measured number; low and high end bracket the measured number.
By their numbers in this assay, from the lowest: compound 3; then compounds 2, 1 and 4 (each within the scatter of the next).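

In this assay, ethoxy in place of hydrogen on an aromatic carbon, ortho to a large group, gives a 1.5-fold higher number from compound 2 to compound 4 (0.17 log units; within the scatter), the only step shown at this place. A short alkoxy chain here therefore leaves the number within the scatter of the unsubstituted compound, which holds for this one group only. No measurement at hand offers an explanation for this result.

From the compounds shown here alone, whether an amine or a carboxylic acid at this place would shift the number beyond the scatter stays open. Compound 3 differs from the others in more than one place, so which change accounts for its 3230 nM also stays open.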